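A few compounds are considered here, and "the series" means these few. Any claim that something is new, unique, unknown or untested is made for them only; others in the source may bear on it.

In a functional assay on HepG2 cells (Homo sapiens) for antiproliferative activity, read by MTT assay, with a stated time of 48 h (a lower number here means a stronger inhibitor, a higher number a weaker inhibitor), compound 1 `COc1ccc(-c2ccc3c(c2)C(=O)C(=O)N3c2ccc(OC)cc2)cc1` gives > 10000 nM, which is a limit of the assay and not a number. Compound 2 `COc1ccc(-c2ccc3c(c2)C(=O)C(=O)N3Cc2cc(C)cc(C)c2)cc1` gives 410 nM, and compound 3 `COc1ccc(CN2C(=O)C(=O)c3cc(-c4cc(OC)cc(OC)c4)ccc32)cc1` gives 1200 nM, the higher of these two numbers. Compound 4 `COc1ccc(CN2C(=O)C(=O)c3cc(-c4ccc(Cl)cc4)ccc32)cc1` carries 4-chlorophenyl in place of the 3,5-dimethoxyphenyl of compound 3 on an aromatic carbon (4-chlorophenyl in place of 3,5-dimethoxyphenyl on an aromatic carbon). Going by the values given here, the one measured step, an at least 24-fold lower number from compound 1 to compound 2 (1.38 log units; beyond the scatter), is large, but it concerns the group on a nitrogen and bears only indirectly on this aromatic carbon. Among the compounds with values here, with no step measured at this place, no shift beyond the scatter is expected in this assay. The expected step is a 1.3-fold higher number from compound 3 to compound 4 (0.10 log units; within the scatter). The value expected for compound 4 is 1500 nM, with an estimated range from 400 nM to 6000 nM.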

Compound 4, half-maximal inhibitory concentration: 380 nM
For compound 4 the middle estimate is 3.9-fold (0.60 log units) above the measured one, and the stated range ends above it.
By their numbers in this assay, from the lowest: compounds 4 and 2 (each within the scatter of the next); then compound 3. At a limit, above all of these: compound 1.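

In this assay the aryl group on this aromatic carbon proves able to move the number: the change gives a 3.2-fold lower number from compound 3 to compound 4 (0.50 log units; beyond the scatter), so the group on the nitrogen is no longer the only place with a measured effect. The swap removes both methoxy groups and adds a chlorine in one step, so the two cannot be separated. Nothing measured here explains the shift. Going by these compounds, whether an amine or a carboxylic acid on this phenyl ring would lower the number further remains open, as does whether the swap holds with 3,5-dimethylbenzyl on the nitrogen.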